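Replacing the Proline Acid with Glycine in a Purine Series

This account rests on a few compounds, and the source may have more. Where it says the series, first, only, none or still open, it means among the compounds named here.

Measured so far:
- compound 1 `O=C(O)[C@@H]1CCCN1C(=O)CN(c1nc(Cl)nc2[nH]cnc12)C1CC1` — 31.5%
- compound 2 `O=C(OCc1ccccc1)[C@@H]1CCCN1C(=O)CN(c1nc(Cl)nc2[nH]cnc12)C1CC1` — 33.2%

Of the compounds shown here, two have been tested in a functional assay on the whole organism (Tail, strain ICR) with Mus musculus as the target, in the tail flick test, with a stated time of 30 min, at a dose of 25 umol/kg by the oral route; a lower number here means a weaker effect, a higher number a stronger effect of the compound at the dose given. Compound 1 gives 31.5%, the lower of the two numbers, and compound 2 gives 33.2%. For the measured compounds named here, the single measured step, a number 1.7 percentage points higher from compound 1 to compound 2 (within the scatter), lies within the scatter, so the two values show no difference that can be read as a change.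

Compound 3 `O=C(O)CNC(=O)CN(c1nc(Cl)nc2[nH]cnc12)C1CC1` has not yet been measured. It differs from compound 1 in the following way: (carboxymethyl)amino in place of 2-carboxypyrrolidin-1-yl on a carbonyl carbon. Going by the values given here, no measured step in this assay bears on this change; the only step available concerns the ester end of the molecule, not the cyclic amino acid. Among the compounds with values here, with no step to draw on, the expectation for compound 3 is that it stays close to compound 1, with a correspondingly wide range. Compound 3 is therefore expected to give 30%, within 15% to 45%, which amounts to an estimated step of a number 1.5 percentage points lower from compound 1 to compound 3 (within the scatter).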

Compound 3, a percentage reported as activity, at one dose (the size of the read-out at that dose, not a potency): 32.2%
For compound 3 the middle estimate is 2.2 percentage points below the measured one; the measured number falls inside the stated range.
By their numbers in this assay, from the lowest: compounds 1, 3 and 2 (each within the scatter of the next).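

In this assay the exchange of 2-carboxypyrrolidin-1-yl for (carboxymethyl)amino on a carbonyl carbon gives a number 0.7 percentage points higher from compound 1 to compound 3 (within the scatter) and so does not separate the two groups at this position. The earlier pair spoke only to the ester end of the molecule, whereas this step touches the cyclic amino acid itself: the five-membered non-aromatic ring and the defined stereocentre both leave with 2-carboxypyrrolidin-1-yl, and the read-out at the dose given shows no difference that can be tied to their removal. No available evidence bears on why the two groups read alike in this assay.

The compounds shown leave open how a longer chain ending in the carboxylic acid, or an amine in place of that acid, would read on the same carbonyl carbon, and whether a benzyl ester of (carboxymethyl)amino would stay level with compound 2. They also leave open whether the likeness of compound 1 and compound 3 holds beyond this single dose and time, since one read-out at one dose is not a measure of potency.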